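A few compounds are considered here, and "the series" means these few. Any claim that something is new, unique, unknown or untested is made for them only; others in the source may bear on it.

Three close relatives of one shared core have been tested in an assay on isolated protein for inhibition of stearoyl-CoA desaturase 5 (Homo sapiens) (on this read-out higher numbers stand for weaker inhibition and lower numbers for stronger inhibition), and each of them reaches only a limit of the measurement rather than a number. Compound 1 `N#Cc1ccc2nc(-c3ccc(-c4ccccc4F)cc3)[nH]c2c1` gives > 20000 nM in this assay, which is a limit. Compound 2 `CCS(=O)(=O)c1ccc2nc(-c3ccc(-c4ccccc4F)cc3)[nH]c2c1` gives > 20000 nM in this assay, again a limit. The step that the two limits leave unreadable from compound 1 to compound 2 therefore cannot be read. As far as these compounds go, compound 3 `CS(=O)(=O)c1ccc2nc(-c3ccc(-c4ccccc4)cc3)[nH]c2c1` gives > 10000 nM in this assay, once more a limit, so where it truly stands is unknown. Compound 4 `CS(=O)(=O)c1ccc2nc(-c3ccc(-c4ccncc4)cc3)[nH]c2c1` differs from compound 3 by pyridin-4-yl in place of phenyl on an aromatic carbon. Among the compounds with values here, no measured step touches this change, and compound 3 is itself only a limit. Compound 4 is therefore expected to remain weak, estimated at 15000 nM within a range of 3000 nM to 60000 nM. The expected step is a step that the limit leaves unreadable from compound 3 to compound 4.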

Compound 4, half-maximal inhibitory concentration: > 20000 nM
Compound 4: no number, only a limit; the forecaster's own chance of this, stated with the estimate: 65%; middle value at least 1.3-fold (0.12 log units) from the limit.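

Compound 3 and compound 4 each reach only a limit of the measurement, and the step between them, pyridin-4-yl in place of phenyl, cannot be read. The compounds shown leave open how strongly any of them truly inhibits the protein.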